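A few compounds are considered here, and "the series" means these few. Any claim that something is new, unique, unknown or untested is made for them only; others in the source may bear on it.

The series shares the core of compound 1 `CC(C)n1nc(-c2ccon2)c2c(N)ncnc21`, which in an assay on isolated protein for inhibition of proto-oncogene tyrosine-protein kinase receptor Ret variant V804M (Homo sapiens), read by radiometric assay and 33P incorporation, in the presence of a further agent that is not named here (on this read-out higher numbers stand for weaker inhibition and lower numbers for stronger inhibition), gives 903 nM, the second highest of the three numbers measured. Going by the values given here, compound 3 `CC(C)n1nc(/C=N/O)c2c(N)ncnc21` gives 3680 nM; the one single-point step is a 4.1-fold higher number from compound 1 to compound 3 (0.61 log units; beyond the scatter). Among the compounds with values here, compound 2 `Nc1ncnc2c1c(-c1cc(C3CC3)on1)nn2C1CCCCC1` gives 14 nM, but it differs from compound 1 in two places, so its value shows only that both changes together go with a far lower number. Compound 4 `CCc1cc(-c2nn(C(C)C)c3ncnc(N)c23)no1` carries ethyl in place of hydrogen on an aromatic carbon. Within the data shown here, no measured step bears on this change alone; a 4.1-fold higher number from compound 1 to compound 3 (0.61 log units; beyond the scatter) concerns another part of the molecule. Among the measured compounds shown here, the only hint is compound 2 with 14 nM, where a cyclopropyl is present. For compound 4 a modest lowering in this assay is expected, a 3.2-fold lower number from compound 1 to compound 4 (0.51 log units; beyond the scatter). Compound 4 is estimated at 280 nM, range 80 nM to 1000 nM.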

Compound 4, half-maximal inhibitory concentration: 531 nM
Compound 4: the middle estimate sits 1.9-fold (0.28 log units) below what was measured, within the range that was stated.
By their numbers in this assay, from the lowest: compound 2; then compounds 4 and 1 (each within the scatter of the next); then compound 3.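

Ethyl in place of hydrogen on this aromatic carbon, next to the ring oxygen, now has a direct single-change reading in this assay. The step is a 1.7-fold lower number from compound 1 to compound 4 (0.23 log units; within the scatter), so compound 1 and compound 4 cannot be told apart on this read-out, and this position accepts ethyl without a measurable loss. No measurement on hand gives a reason for this result.

Open, on these data alone, is whether an amine or a longer chain on this carbon would read differently from ethyl. Also open, as far as these compounds go, is how cyclopropyl here would read with the rest of compound 1 unchanged.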